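Adding a Fluoro Group to Compound 1

The source may hold more compounds than are shown below. What is called first, only, known or untested is meant among the compounds shown, and "the series" means these compounds.

In an ADME assay on cells (Macrophage, Mus musculus) for cytotoxicity, read by resazurin assay, with a stated time of 3 days (on this read-out lower numbers stand for stronger inhibition and higher numbers for weaker inhibition), compound 1 (`O=C(Nc1cccc(C(F)(F)F)c1)c1cc(Cl)ccc1O`) gives 5900 nM and compound 2 (`Cc1c(NC(=O)c2cc(Cl)ccc2O)cccc1C(F)(F)F`) gives 8000 nM in the same test. These two numbers lie within the scatter of each other, so compound 1 cannot yet be placed apart from compound 2. Compound 3 (`O=C(Nc1ccc(F)c(C(F)(F)F)c1)c1cc(Cl)ccc1O`) differs from compound 1 in one place (fluoro in place of hydrogen on an aromatic carbon): fluoro in place of hydrogen on an aromatic carbon, ortho to a trifluoromethyl group and para to a large group. Among the measured compounds shown here, the only measured step that bears on this is methyl in place of hydrogen on an aromatic carbon, a 1.4-fold higher number from compound 1 to compound 2 (0.13 log units; within the scatter) and it involves a different group, so it is a loose guide. No step beyond the scatter is therefore expected in this assay for this change. The estimate amounts to a 1.1-fold lower number from compound 1 to compound 3 (0.03 log units; within the scatter) as an expected step. Compound 3 is estimated at 5500 nM within an expected range from 2500 nM to 12000 nM in this test.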

Compound 3, half-maximal inhibitory concentration: 5300 nM
For compound 3 the middle estimate is 1.0-fold (0.02 log units) above the measured one, within the range that was stated.
By their numbers in this assay, from the lowest: compounds 3, 1 and 2 (each within the scatter of the next).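

In this assay, fluoro in place of hydrogen on an aromatic carbon, ortho to a trifluoromethyl group and para to a large group, gives a 1.1-fold lower number from compound 1 to compound 3 (0.05 log units; within the scatter) and so leaves compound 3 not separable from compound 1. Among the compounds shown here, this is the first reading for a change at this carbon, since the methyl group of compound 2 sits on a different one, and it shows that a fluoro here produces no step that can be told from the scatter. No measurement on hand offers an explanation for this result.

Going by these compounds, it remains open whether a methoxy group, an amine or a carboxylic acid at this carbon would produce a step beyond the scatter. All the compounds shown carry the trifluoromethyl group, so what replacing it would do also remains open.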